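Methyl to fluoro on the phenyl of the shared core

This account rests on a few compounds, and the source may have more. Where it says the series, first, only, none or still open, it means among the compounds named here.

Of the compounds shown here, two have numbers so far. Compound 1 `O=C1CC(c2nc(-c3ccccc3)no2)CN1c1ccccc1` gives 350 nM in an in vitro functional assay on HEK293-A cells for positive allosteric modulation of metabotropic glutamate receptor 5 (Homo sapiens), read by FLIPR and calcium flux; a higher number here means that more compound is needed for the effect, a lower number that less compound is needed. Compound 2 `Cc1cccc(-c2noc(C3CC(=O)N(c4ccc(Cl)cc4)C3)n2)c1` gives 170 nM in this assay, the lowest of the two numbers; the gap to compound 1 is beyond the scatter, so compound 2 stands as the more potent of the two.

Compound 3 `O=C1CC(c2nc(-c3cccc(F)c3)no2)CN1c1ccc(Cl)cc1` has not yet been measured in this assay. It differs from compound 2 in one place: fluoro in place of methyl on an aromatic carbon. Going by the values given here, no measured pair isolates this change, so there is no step to lean on, and the carried-over part of the structure is otherwise the same as in compound 2.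

Expectation: the step from compound 2 to compound 3 in this assay is estimated to be small, most likely within the scatter, with a slight lean toward a higher number, so a 1.5-fold higher number from compound 2 to compound 3 (0.17 log units; within the scatter) is expected. Compound 3 is estimated to give 250 nM in this assay, within a range from 100 nM to 650 nM.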

Compound 3, half-maximal effective concentration: 630 nM
For compound 3 the middle estimate is 2.5-fold (0.40 log units) below the measured one; measured number inside the range.
By their numbers in this assay, from the lowest: compound 2; then compounds 1 and 3 (each within the scatter of the next).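

Going by these compounds alone, the first matched pair of the series shows that this position, meta to a large group on the phenyl, is sensitive to its substituent: in this assay the change from 3-methylphenyl to 3-fluorophenyl gives a 3.7-fold higher number from compound 2 to compound 3 (0.57 log units; beyond the scatter) with the rest of the structure held constant. The exchange swaps one heavy atom for one heavy atom and leaves the counts of hydrogen-bond donors and acceptors and the net charge unchanged, so a step beyond the scatter can arise here without any difference in those counts. No measurement at hand bears on the origin of this step.

The pair cannot separate a gain from the methyl and a loss from the fluoro, and a hydrogen, chloro, methoxy or ethyl group at this same place with the rest of compound 2 would be needed to place both on one scale. Also open, on these data alone, is whether the step from methyl to fluoro keeps its size when the other aromatic ring of the shared core carries a different substituent.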